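Aryl swap on the ring nitrogen: estimating compound 4

The compounds below may be only part of what the source reports. "The series", "measured", "known", "first", "only" and "open" are said of these compounds alone.

Compound 1 `N#CC1=C(N)Oc2c(N)cc3nc4ccccc4nc3c2C12C(=O)N(Cc1cnnn1-c1ccccc1Br)c1ccccc12`: 38000 nM in a functional assay on HepG2 cells (Homo sapiens) for antiproliferative activity, read by MTT assay, with a stated time of 48 h; a higher number here means a weaker inhibitor, a lower number a stronger inhibitor.
Compound 2 `N#CC1=C(N)Oc2c(N)cc3nc4ccccc4nc3c2C12C(=O)N(Cc1cnnn1-c1cccc(C(F)(F)F)c1)c1ccccc12`: 15800 nM in this assay.
Compound 3 `N#CC1=C(N)Oc2c(N)cc3nc4ccccc4nc3c2C12C(=O)N(Cc1cnnn1-c1ccc([N+](=O)[O-])cc1)c1ccccc12`: > 50000 nM in this assay, a limit of the assay rather than a number.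

For compound 3 only that limit is known, (the limit of > 50000 nM in this assay, at which 1 of the 3 values shown sits). Compound 4 `Cc1ccc(-n2nncc2CN2C(=O)C3(C(C#N)=C(N)Oc4c(N)cc5nc6ccccc6nc5c43)c3ccccc32)cc1C` differs from it in one place: 3,4-dimethylphenyl in place of 4-nitrophenyl on an aromatic nitrogen. For the measured compounds named here, two measured steps bear on this change. Exchanging 2-bromophenyl for 4-nitrophenyl gave an at least 1.3-fold higher number from compound 1 to compound 3 (0.11 log units; that floor lies within the scatter), and exchanging 3-(trifluoromethyl)phenyl for 4-nitrophenyl gave an at least 3.1-fold higher number from compound 2 to compound 3 (0.50 log units; beyond the scatter). In both, the number moved up to the limit, so replacing 4-nitrophenyl with 3,4-dimethylphenyl is expected to bring the number in this assay back down toward those of compound 1 and compound 2. Compound 4 is therefore estimated at 25000 nM, with a range of 10000 nM to 60000 nM. For compound 4 this means an expected step of an at least 2.0-fold lower number from compound 3 to compound 4 (0.30 log units; that floor lies within the scatter).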

Compound 4, half-maximal inhibitory concentration: > 50000 nM
Compound 4 ended at the assay's limit (the forecaster's own chance of this, stated with the estimate: 25%); middle value at least 2.0-fold (0.30 log units) away from the limit.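

In this assay compound 4 reaches the same limit of the assay as compound 3, so that limit at this position is not confined to 4-nitrophenyl, and the step between the two cannot be read. 3,4-Dimethylphenyl, with no hydrogen-bond acceptors, gives an at least 3.1-fold higher number from compound 2 to compound 4 (0.50 log units; beyond the scatter). It also gives an at least 1.3-fold higher number from compound 1 to compound 4 (0.11 log units; that floor lies within the scatter), so only the gap to 3-(trifluoromethyl)phenyl is firm.

On these data alone, whether an unsubstituted phenyl, a 4-aminophenyl or a 3-chlorophenyl on this nitrogen would come in under the limit stays open. Any order among the weakest members also stays open, with the series now reading: the limit of > 50000 nM in this assay, at which 2 of the 4 values shown sit.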